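Removing the Last Methyl From Compound 3

This account rests on a few compounds, and the source may have more. Where it says the series, first, only, none or still open, it means among the compounds named here.

Within the data shown here, compound 3 `Cc1ccnc2nc(-c3ccc4ccccc4c3)cc(O)c12` gives 427 nM in a functional assay on HCT-116 cells (Homo sapiens) for antiproliferative activity (on this read-out higher numbers stand for weaker inhibition of growth and lower numbers for stronger inhibition of growth), the lowest of the three numbers so far. Compound 1 `Cc1cnc2nc(-c3ccc4ccccc4c3)cc(O)c2c1` gives 468 nM, and the two lie within the scatter of each other, so nothing separates them. Among the measured compounds shown here, compound 2 `Cc1cc(C)c2c(O)cc(-c3ccc4ccccc4c3)nc2n1` gives 12600 nM, far higher than both; the single step from it, a 30-fold lower number from compound 2 to compound 3 (1.47 log units; beyond the scatter), shows that taking away one methyl produced a large gain.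

Compound 4 `Oc1cc(-c2ccc3ccccc3c2)nc2ncccc12` has not yet been measured. It differs from compound 3 by hydrogen in place of methyl on an aromatic carbon, the methyl ortho to a fused ring and opposite the ring nitrogen being lost. For the measured compounds named here, the one comparable step, a 30-fold lower number from compound 2 to compound 3 (1.47 log units; beyond the scatter), concerned a methyl at a different place, so it bears only loosely on this change; that compound 1 and compound 3 carry methyls at different places yet give the same number suggests the remaining methyl contributes little. Compound 4 is therefore expected to stay close to compound 3, with a small step of a 1.2-fold lower number from compound 3 to compound 4 (0.09 log units; within the scatter) if any, estimated at 350 nM within 120 nM to 1200 nM.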

Compound 4, concentration for 50% growth inhibition: 3800 nM
Compound 4: middle estimate off by 11-fold (1.04 log units), on the low side, and the stated range ends below it.
By their numbers in this assay, from the lowest: compounds 3 and 1 (each within the scatter of the next); then compound 4; then compound 2.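

In this assay, taking away the last methyl costs activity, giving an 8.9-fold higher number from compound 3 to compound 4 (0.95 log units; beyond the scatter), and the same holds for the methyl at the other place, giving an 8.1-fold higher number from compound 1 to compound 4 (0.91 log units; beyond the scatter), so the match between compound 1 and compound 3 did not mean that these methyls contribute little. Either single methyl gives a lower number than the unsubstituted compound 4, though compound 2, with two methyls, goes against any rule that more methyl helps. Hydrogen in place of methyl on an aromatic carbon therefore has no fixed effect here, and its direction reverses with the core: the same change on two cores in this assay, a 30-fold lower number (1.47 log units; beyond the scatter) from compound 2 to compound 3 and an 8.1-fold higher number (0.91 log units; beyond the scatter) from compound 1 to compound 4, 240-fold (2.38 log units) apart, beyond the scatter of two such steps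

The compounds shown leave open whether this position needs a methyl as such or would serve equally well with an ethyl, a methoxy or an amine. They also cannot tell why one methyl lowers the number while a further one raises it.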